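Series notes: from compound 3 to compound 4

The source may report more compounds than this note shows. Statements on the series, on what has been measured and on what is new or still open speak of the compounds shown alone.

compound 1 `COc1cccc(NC(=O)c2cc(=O)[nH]c3cc(Br)ccc23)c1` — > 20000 nM in a functional assay on KYSE-70 cells for antiproliferative activity against KYSE-70 cell line (Homo sapiens), read by MTT assay, with a stated time of 72 h (on this read-out higher numbers stand for weaker inhibition and lower numbers for stronger inhibition), a limit
compound 2 `O=C(Nc1cc(F)c(F)c(F)c1)c1cc(=O)[nH]c2cc(Br)ccc12` — > 20000 nM, a limit
compound 3 `O=C(Nc1cccc(F)c1)c1cc(=O)[nH]c2cc(-c3ccccc3)ccc12` — > 20000 nM, a limit

Compound 3 stands at the limit of this assay and not at a number; every value shown sits there, as the limit of > 20000 nM in this assay, at which 3 of the 3 values shown sit, records. Compound 4 `O=C(Nc1cccc(F)c1)c1cc(=O)[nH]c2cc(C3=CCOCC3)ccc12` is not yet measured. It differs from compound 3 in one place: a group of 6 heavy atoms (5 carbon, 1 oxygen; one six-membered non-aromatic ring with 1 hetero atom) in place of a group of 6 heavy atoms (6 carbon; one six-membered aromatic ring of carbon only), on an aromatic carbon. Within the data shown here, no step between two measured compounds is available, so no direction or size of change in this assay can be drawn from the series; the expectation is for no step beyond the scatter, as the estimated step that the limit leaves unreadable from compound 3 to compound 4 expresses. Compound 4 is expected at 25000 nM, with a range from 6000 nM to 100000 nM.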

Compound 4, half-maximal inhibitory concentration: 10500 nM
Beside the measured number, compound 4's estimate is 2.4-fold (0.38 log units) above it; the measured number falls inside the stated range.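

In this assay, replacing phenyl with the six-membered non-aromatic ring with 1 hetero atom on this aromatic carbon gives an at least 1.9-fold lower number from compound 3 to compound 4 (0.27 log units; that floor lies within the scatter). Compound 4 is the only compound shown with a number and not a limit, so this position is the one place in the series where a change has registered, though only with a floor inside the scatter. The rest of the series offers no number to set against it: the limit of > 20000 nM in this assay, at which 3 of the 4 values shown sit.

As far as these compounds go, whether the ring oxygen or the double bond outside aromatic rings matters more remains open. Also open, from the compounds shown here alone, is what an amine, a carboxylic acid or a longer chain would give at this position.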